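One methoxy fewer: what to expect of compound 3

The source may hold more compounds than are shown below. What is called first, only, known or untested is meant among the compounds shown, and "the series" means these compounds.

In a physicochemical assay for lipophilicity (on this read-out lower numbers stand for lower lipophilicity and higher numbers for higher lipophilicity), compound 1 `COc1ccc(C(=O)/C=C/c2ccc(OC)c(OC)c2)c(O)c1` reads 3.53 and compound 2 `COc1ccc(C(=O)/C=C/c2cc(OC)c(OC)c(OC)c2)c(O)c1` reads 3.49 on the same scale. For the measured compounds named here, compound 1 therefore stands within the scatter of the only other measured compound, and neither can be placed ahead of the other.

Compound 3 `COc1cccc(/C=C/C(=O)c2ccc(OC)cc2O)c1` has not yet been measured. It carries hydrogen in place of methoxy on an aromatic carbon of compound 1 (hydrogen in place of methoxy on an aromatic carbon), at a carbon ortho to a methoxy group and para to a large group.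

Going by the values given here, one measured step bears on this change. Compound 2 has methoxy in place of hydrogen at a different carbon, which is the same kind of swap run the other way, and the result was a number 0.04 log units lower from compound 1 to compound 2 (within the scatter) in this assay on the scale. A single step at another carbon is thin evidence, so it serves only as a guide. No shift beyond the scatter is expected, and the data give no firm direction. The estimated step is a number 0.04 log units higher from compound 1 to compound 3 (within the scatter) and stays within the scatter. Compound 3 is estimated to read 3.57 within a range of 3.25 to 3.85 on this scale.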

Compound 3, partition coefficient: 3.86
For compound 3 the middle estimate is 0.29 log units below the measured one; measured number above the stated range.
By their numbers in this assay, from the lowest: compounds 2 and 1 (each within the scatter of the next); then compound 3.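

On this assay, hydrogen in place of methoxy at this carbon, ortho to a methoxy group and para to a large group, gives a number 0.33 log units higher from compound 1 to compound 3 (beyond the scatter) and so moves the read-out by more than the usual scatter. For the compounds shown here, the only earlier step, methoxy in place of hydrogen at a different carbon, was a number 0.04 log units lower from compound 1 to compound 2 (within the scatter) and gave no readable change, so the two steps show that a swap of these two substituents need not read the same at every carbon of the shared core. Nothing available explains why this carbon gives a step beyond the scatter while the other does not.

The compounds shown leave open how this same carbon would read with a substituent other than hydrogen or methoxy, such as an amine, a carboxylic acid or a longer chain in place of the methoxy. They also leave open whether removing each of the other methoxy groups on the core would give a step of this size or one that stays within the scatter.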